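This account rests on a few compounds, and the source may have more. Where it says the series, first, only, none or still open, it means among the compounds named here.

Compounds measured so far in a functional assay, tested at 100 ug/mL; on this read-out lower numbers stand for a weaker effect and higher numbers for a stronger effect at the one concentration tested:

compound 1, `N#CC1=C(N)OC(c2c[nH]c3ccccc23)=C(C#N)C1c1ccccc1Cl`, gives 10.4%
compound 2, `CN(C)c1ccc(C2C(C#N)=C(N)OC(c3c[nH]c4ccccc34)=C2C#N)cc1`, gives 18.5%
compound 3, `Cc1ccccc1C1C(C#N)=C(N)OC(c2c[nH]c3ccccc23)=C1C#N`, gives 17.2%

Compound 3 holds the second highest of the three numbers. Its nearest neighbour is compound 2, with a number 1.3 percentage points lower from compound 2 to compound 3 (within the scatter), and its furthest is compound 1, with a number 6.8 percentage points higher from compound 1 to compound 3 (within the scatter); both gaps sit within the usual scatter, so the three compounds cannot be told apart on this read-out.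

The next compound, compound 4, is `COc1ccc(C2C(C#N)=C(N)OC(c3c[nH]c4ccccc34)=C2C#N)cc1`. It differs from compound 3 in one place: 4-methoxyphenyl in place of 2-methylphenyl on a saturated ring carbon.

Going by the values given here, two measured steps bear on this change, since both swap the aryl group on the same saturated ring carbon: a number 8.1 percentage points higher from compound 1 to compound 2 (within the scatter) and a number 1.3 percentage points lower from compound 2 to compound 3 (within the scatter). Among the compounds with values here, neither rose above the scatter, and no step in this set did. The expected step to compound 4 in this assay is therefore none beyond the scatter, at a number 0.2 percentage points lower from compound 3 to compound 4 (within the scatter).

Compound 4 is estimated to give 17%, within a range from 8% to 27%.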

Compound 4, a percentage reported as activity, at one concentration (the size of the read-out at that concentration, not a potency): 20%
Compound 4: the middle estimate sits 3 percentage points below what was measured; low and high end bracket the measured number.
By their numbers in this assay, from the lowest: compounds 1, 3, 2 and 4 (each within the scatter of the next).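

In this assay the 4-methoxyphenyl group on the saturated ring carbon, which brings one oxygen and one hydrogen-bond acceptor that 2-methylphenyl lacks, gives a step that cannot be told from the scatter (a number 2.8 percentage points higher from compound 3 to compound 4 (within the scatter)). The other two aryl groups at this position give the same picture (a number 1.5 percentage points higher from compound 2 to compound 4 (within the scatter)) and (a number 9.6 percentage points higher from compound 1 to compound 4 (within the scatter)), so all four compounds remain indistinguishable on this read-out, and methoxy in place of dimethylamino on the aromatic carbon makes no readable difference. Nothing measured here offers an explanation for these numbers.

The compounds shown leave open whether any group at this position can move the read-out beyond the scatter, such as a carboxylic acid or a longer chain on the phenyl ring. They also leave open how these compounds would compare at other concentrations, since a single concentration gives no potency.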